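Amide aryl variation on the shared core: pyridin-3-yl next

A few compounds are considered here, and "the series" means these few. Any claim that something is new, unique, unknown or untested is made for them only; others in the source may bear on it.

Among the compounds with values here, compound 3 `CCN1CCN(c2cc(C)c3cc(NC(=O)c4ccc5ccccc5n4)ccc3n2)CC1` gives 7060 nM in a functional assay on MCF7 cells (Homo sapiens) for antiproliferative activity, read by MTT assay, with a stated time of 72 h (on this read-out higher numbers stand for weaker inhibition and lower numbers for stronger inhibition), the second highest of the three numbers so far. Compound 1 `CCN1CCN(c2cc(C)c3cc(NC(=O)c4cccc(Cl)c4)ccc3n2)CC1` gives 3820 nM and compound 2 `CCc1ccccc1C(=O)Nc1ccc2nc(N3CCN(CC)CC3)cc(C)c2c1` gives 15800 nM. The steps among them are a 1.8-fold higher number from compound 1 to compound 3 (0.27 log units; within the scatter) and a 2.2-fold lower number from compound 2 to compound 3 (0.35 log units; beyond the scatter), with a 4.1-fold higher number from compound 1 to compound 2 (0.62 log units; beyond the scatter) spanning the set. Compound 4 `CCN1CCN(c2cc(C)c3cc(NC(=O)c4cccnc4)ccc3n2)CC1` differs from compound 3 by pyridin-3-yl in place of quinolin-2-yl on a carbonyl carbon. Within the data shown here, no measured step introduces pyridin-3-yl, so only the range of the three aryl amides guides the expectation; none of the steps exceeds a modest size, so compound 4 is expected to stay within that range, giving an expected step of a 1.0-fold lower number from compound 3 to compound 4 (0.00 log units; within the scatter). Compound 4 is therefore estimated at 7000 nM, between 2500 nM and 20000 nM.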

Compound 4, half-maximal inhibitory concentration: 26600 nM
Estimate against measurement, compound 4: 3.8-fold (0.58 log units) below; measured number outside the range, above it.
By their numbers in this assay, from the lowest: compounds 1 and 3 (each within the scatter of the next); then compounds 2 and 4 (each within the scatter of the next).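

In this assay, within the data shown here, the aryl group on the carbonyl carbon now shows a wider spread: pyridin-3-yl, which lacks the carbon-only aromatic ring of quinolin-2-yl, gives a 3.8-fold higher number from compound 3 to compound 4 (0.58 log units; beyond the scatter) and, in place of 3-chlorophenyl, gives a 7.0-fold higher number from compound 1 to compound 4 (0.84 log units; beyond the scatter) as the largest step so far. In place of 2-ethylphenyl it gives a 1.7-fold higher number from compound 2 to compound 4 (0.23 log units; within the scatter) so compounds 2 and 4 cannot be ordered. No evidence on the cause of these steps is at hand.

Compound 1 and compound 4 differ in both the ring nitrogen and the chlorine, and the set does not separate the two. As far as these compounds go, what an unsubstituted phenyl, or a phenyl carrying an amine or a carboxylic acid, would give stays open.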